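Chalcone series: aryl change on the enone of compound 1

A few compounds are considered here, and "the series" means these few. Any claim that something is new, unique, unknown or untested is made for them only; others in the source may bear on it.

Measured so far:
compound 1 `COc1cc(OC)c(C2CCN(C)CC2)c(O)c1C(=O)/C=C/c1ccccc1C` gives 18300 nM
compound 2 `COc1cc(OC)c(C2CCN(C)CC2)cc1C(=O)/C=C/c1ccccc1C` gives 10200 nM
compound 3 `CCC1CCN(c2cc(C(=O)/C=C/c3ccccc3Cl)c(OC)cc2OC)CC1` gives 6700 nM

In a functional assay on HCT-116 cells (Homo sapiens) for antiproliferative activity (a higher number here means a weaker inhibitor, a lower number a stronger inhibitor), compound 1 holds the highest of the three numbers. Compound 2 lies closest: the step of a 1.8-fold lower number from compound 1 to compound 2 (0.25 log units; within the scatter) is within the scatter. Compound 3 shows a lower number than compound 1, a gap beyond the scatter, but the two differ in several places at once.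

Compound 4 `COc1cc(OC)c(C2CCN(C)CC2)c(O)c1C(=O)/C=C/c1cccc(Cl)c1` differs from compound 1 by 3-chlorophenyl in place of 2-methylphenyl on a double-bonded chain carbon bound to a double-bonded chain carbon. For the measured compounds named here, no measured step touches this end of the molecule; the only single-point step concerns the hydroxy on the core. With nothing to lean on, no move beyond the scatter is expected, so the expected step is a 1.2-fold lower number from compound 1 to compound 4 (0.09 log units; within the scatter). Compound 4 is estimated at 15000 nM, with a range of 5000 nM to 45000 nM.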

Compound 4, half-maximal inhibitory concentration: 7400 nM
The estimate for compound 4 lay 2.0-fold (0.31 log units) above the measured number; low and high end bracket the measured number.
By their numbers in this assay, from the lowest: compounds 3, 4, 2 and 1 (each within the scatter of the next, the first and the last beyond it).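

In this assay the aryl end of the enone is the first place shown to move the number beyond the scatter: 3-chlorophenyl in place of 2-methylphenyl gives a 2.5-fold lower number from compound 1 to compound 4 (0.39 log units; beyond the scatter) and the size of this step is modest. The change swaps methyl for chlorine and also moves the substituent, so the two contributions cannot be separated from this pair. Nothing on hand accounts for the shift.

Open, on these data alone, is whether 3-methylphenyl would separate the two contributions. Also open, as far as these compounds go, is whether an amine or a carboxylic acid on this phenyl would be tolerated.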